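The compounds below may be only part of what the source reports. "The series", "measured", "known", "first", "only" and "open" are said of these compounds alone.

Among the measured compounds shown here, compound 2 `O=c1ccc2cc(OCc3cn(-c4ccccc4)nn3)ccc2o1` is one of two compounds measured in a functional assay on HL-60 cells (Homo sapiens) for cytotoxicity, read by MTT assay, with a stated time of 48 h; a lower number here means a stronger inhibitor, a higher number a weaker inhibitor. In this assay compound 2 gives 41600 nM. Compound 1 `O=c1ccc2cc(OCc3cc(-c4cccc([N+](=O)[O-])c4)no3)ccc2o1`, which also carries a nitro group, gives 44400 nM in this assay, and the two numbers lie within the scatter of each other. Compound 3 `O=c1ccc2cc(OCc3cn(-c4ccc([N+](=O)[O-])cc4)nn3)ccc2o1` differs from compound 2 by nitro in place of hydrogen on an aromatic carbon. For the measured compounds named here, no step between measured compounds is available to size this change. The expected step is none beyond the scatter, a 1.0-fold lower number from compound 2 to compound 3 (0.02 log units; within the scatter). Compound 3 is therefore expected to give about 40000 nM in this assay, with a range from 15000 nM to 100000 nM.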

Compound 3, half-maximal inhibitory concentration: 46000 nM
Compound 3: middle estimate off by 1.2-fold (0.06 log units), on the low side; the range from low to high includes it.
By their numbers in this assay, from the lowest: compounds 2, 1 and 3 (each within the scatter of the next).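

In this assay the change from phenyl to 4-nitrophenyl gives a 1.1-fold higher number from compound 2 to compound 3 (0.04 log units; within the scatter) and so leaves the number within the scatter. Among the compounds shown here, this is the first direct reading of nitro in place of hydrogen at this place, para to a large group, as compound 1 differs from compound 2 in more than one place. Nothing measured here offers an explanation of this result. From the compounds shown here alone, whether an amine or a carboxylic acid at this place would move the number beyond the scatter remains open, as does the effect of nitro on another carbon of this ring.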